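The source may hold more compounds than are shown below. What is called first, only, known or untested is meant among the compounds shown, and "the series" means these compounds.

Working notes, series of decyl-phenyl oxadiazoles bearing a small amine-containing group on the shared core.

Compound 3 `CCCCCCCCCCc1ccc(-c2noc(C(Cl)CCN)n2)cc1` stands lowest of the three numbers in an assay on HeLa cells for inhibition of sphingosine-1-phosphate transporter SPNS2 (Mus musculus), read by LC-MS, tested at 2 uM (a higher number here means more inhibition at the concentration tested (going by the name of the read-out), a lower number less inhibition), giving 5%. Compound 1 `CCCCCCCCCCc1ccc(-c2noc(C3CCNC3)n2)cc1` gives 26%, and compound 2 `CCCCCCCCCCc1ccc(-c2noc([C@H]3CCCN3)n2)cc1` gives 12%. The steps into compound 3 differ in size: a number 21 percentage points lower from compound 1 to compound 3 (beyond the scatter), whereas a number 7 percentage points lower from compound 2 to compound 3 (within the scatter). Between the two ring-bearing compounds, a number 14 percentage points lower from compound 1 to compound 2 (beyond the scatter).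

Compound 4 `CCCCCCCCCCc1ccc(-c2noc([C@H](N)CCCCN)n2)cc1` is not yet measured. Its difference from compound 3 is a group of 7 heavy atoms (5 carbon, 2 nitrogen; no ring) in place of a group of 5 heavy atoms (3 carbon, 1 nitrogen, 1 chlorine; no ring), on an aromatic carbon. For the measured compounds named here, neither measured step bears on this change directly: both steps that end at compound 3 swap a five-membered ring for the chloro-bearing chain, and no measured pair swaps that chain for a 1,5-diaminopentyl group. What the numbers do show is that the three compounds span only a modest window, and that the two chain- or ring-bearing groups without a full ring sit at the low end. Going by the values given here, with no comparable step in hand, the expectation for compound 4 is a step of small size, a number 7 percentage points higher from compound 3 to compound 4 (within the scatter), kept close to compound 3 because 5% already sits at the bottom of the range seen.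

Compound 4 is therefore estimated at 12% in this assay, with a range from 0% to 35%.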

Compound 4, a percentage reported as inhibition, at one concentration (the size of the read-out at that concentration, not a potency): 50%
Beside the measured number, compound 4's estimate is 38 percentage points below it; the whole stated range lies below it.
By their numbers in this assay, from the lowest: compounds 3 and 2 (each within the scatter of the next); then compound 1; then compound 4.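

In this assay, for the compounds shown here, the 1,5-diaminopentyl group on an aromatic carbon of the shared core stands clear of all three earlier groups (a number 45 percentage points higher from compound 3 to compound 4 (beyond the scatter); a number 38 percentage points higher from compound 2 to compound 4 (beyond the scatter); a number 24 percentage points higher from compound 1 to compound 4 (beyond the scatter)), so this position can carry a far higher number than the earlier compounds reached. Having no ring does not by itself set the number here: compound 3 and compound 4 both lack a ring, yet they lie far apart, and the step from compound 1 shows that an open chain can also exceed the pyrrolidin-3-yl group. No measured data explain why the 1,5-diaminopentyl group gives this gain.

From the compounds shown here alone, the change alters several things at once, as chlorine leaves, a second nitrogen enters and the chain grows, so it remains open whether a pentyl chain carrying a single amine, a shorter diaminobutyl chain or the mirror-image stereocentre would hold the gain. Going by these compounds, it also remains open whether either amine could give way to a hydroxyl group or a carboxylic acid without losing it.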